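The compounds below may be only part of what the source reports. "The series", "measured", "known", "first", "only" and "open" are said of these compounds alone.

Three compounds built on one shared core were tested in a functional assay on A549 cells (Homo sapiens) for cytotoxicity, read by MTT assay, with a stated time of 48 h; on this read-out higher numbers stand for weaker inhibition and lower numbers for stronger inhibition. Compound 1 `Cc1ccccc1OCC(=O)Nc1nc(-c2ccc(Br)cc2)cs1` gives 50100 nM. Compound 2 `O=C(COc1ccc(F)cc1F)Nc1nc(-c2ccc(Br)cc2)cs1` gives 58800 nM; it differs from compound 1 by 2,4-difluorophenyl in place of 2-methylphenyl on an oxygen on a saturated carbon, and that change made a step of a 1.2-fold higher number from compound 1 to compound 2 (0.07 log units; within the scatter). Compound 3 `Cc1ccccc1OCC(=O)Nc1nc(-c2ccc(Cl)cc2)cs1` gives 64900 nM; its core differs from the core of compound 1 by chloro in place of bromo on an aromatic carbon, a step of a 1.3-fold higher number from compound 1 to compound 3 (0.11 log units; within the scatter). Compound 4 `O=C(COc1ccc(F)cc1F)Nc1nc(-c2ccc(Cl)cc2)cs1` has not been measured. It differs from compound 3 by 2,4-difluorophenyl in place of 2-methylphenyl on an oxygen on a saturated carbon, the same change that separates compound 1 from compound 2, at the same place. Resting on the earlier step of a 1.2-fold higher number from compound 1 to compound 2 (0.07 log units; within the scatter), the expected step in this assay is a 1.1-fold higher number from compound 3 to compound 4 (0.05 log units; within the scatter). Compound 4 is therefore expected to give 72000 nM in this assay, with a likely range of 40000 nM to 130000 nM.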

Compound 4, half-maximal inhibitory concentration: 26500 nM
Beside the measured number, compound 4's estimate is 2.7-fold (0.43 log units) above it, outside the stated range (below it).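

In this assay, 2,4-difluorophenyl in place of 2-methylphenyl made a step of a 2.4-fold lower number from compound 3 to compound 4 (0.39 log units; beyond the scatter), so this change did not carry over unchanged from the bromo core to the chloro core: the same change on two cores in this assay, a 1.2-fold higher number (0.07 log units; within the scatter) from compound 1 to compound 2 and a 2.4-fold lower number (0.39 log units; beyond the scatter) from compound 3 to compound 4, 2.9-fold (0.46 log units) apart, beyond the scatter of two such steps Chloro in place of bromo made a step of a 2.2-fold lower number from compound 2 to compound 4 (0.35 log units; beyond the scatter), which likewise does not match the same change made on the other core: the same change on two cores in this assay, a 1.3-fold higher number (0.11 log units; within the scatter) from compound 1 to compound 3 and a 2.2-fold lower number (0.35 log units; beyond the scatter) from compound 2 to compound 4, 2.9-fold (0.46 log units) apart, beyond the scatter of two such steps The two changes therefore do not simply add in these four compounds, but this single set of four does not show why, or whether the same holds for other groups.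

The compounds shown leave open how a fluoro in place of the chloro on the aromatic carbon would behave. They also leave open whether a longer chain between the oxygen and the amide carbonyl would depend on the core in the same way.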